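A few compounds are considered here, and "the series" means these few. Any claim that something is new, unique, unknown or untested is made for them only; others in the source may bear on it.

Measured compounds:
compound 1 `C=CC(=O)Nc1cccc(NC(=O)CSc2nc(Nc3ccccc3)c3ccccc3n2)c1` – 10200 nM
compound 2 `C=CC(=O)Nc1cccc(NC(=O)CSc2nc(Nc3ccccc3F)c3ccccc3n2)c1` – 18700 nM
compound 3 `C=CC(=O)Nc1cccc(NC(=O)CSc2nc(Nc3cccc(F)c3)c3ccccc3n2)c1` – 8160 nM

All three numbers come from a functional assay on MDA-MB-231 cells (Homo sapiens) for inhibition, read by MTT assay, with a stated time of 72 h; on this read-out lower numbers stand for stronger inhibition and higher numbers for weaker inhibition. Compound 3 gives the lowest number of the three: the step of a 1.3-fold lower number from compound 1 to compound 3 (0.10 log units; within the scatter) stays within the scatter, whereas a 2.3-fold lower number from compound 2 to compound 3 (0.36 log units; beyond the scatter) lies beyond it. Compound 4 `C=CC(=O)Nc1cccc(NC(=O)CSc2nc(Nc3cccc(C)c3)c3ccccc3n2)c1` takes the step (methyl in place of fluoro on an aromatic carbon). Among the measured compounds shown here, no measured pair swaps fluoro for methyl anywhere, so the only steps bearing on this change are the two that touch the fluoro-bearing ring, a 1.3-fold lower number from compound 1 to compound 3 (0.10 log units; within the scatter) and a 2.3-fold lower number from compound 2 to compound 3 (0.36 log units; beyond the scatter), both small. Exchanging one heavy atom for one heavy atom at this position is therefore expected to give no step beyond the scatter in this assay, namely a 1.0-fold lower number from compound 3 to compound 4 (0.01 log units; within the scatter). Compound 4 is estimated at 8000 nM, with a range from 3500 nM to 18000 nM.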

Compound 4, half-maximal inhibitory concentration: 16800 nM
Compound 4: the middle estimate sits 2.1-fold (0.32 log units) below what was measured; the range from low to high includes it.
By their numbers in this assay, from the lowest: compounds 3, 1, 4 and 2 (each within the scatter of the next, the first and the last beyond it).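

In this assay, fluoro and methyl at this place are not interchangeable despite their equal heavy-atom count: a 2.1-fold higher number from compound 3 to compound 4 (0.31 log units; beyond the scatter) is modest but clears the scatter. Neither a 1.6-fold higher number from compound 1 to compound 4 (0.22 log units; within the scatter) nor a 1.1-fold lower number from compound 2 to compound 4 (0.05 log units; within the scatter) clears it, so 3-methylphenyl cannot be separated from phenyl or 2-fluorophenyl, and only 3-fluorophenyl stands apart from the methyl compound. No supporting data explain the fluoro-to-methyl step.

Open, from the compounds shown here alone, is where chloro, methoxy or amino groups at this place would fall relative to fluoro and methyl. Also open, going by these compounds, is how a methyl group would read on the other ring carbons.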